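The source may report more compounds than this note shows. Statements on the series, on what has been measured and on what is new or still open speak of the compounds shown alone.

Series notes. Compound 1 `Cc1ccc(C2=NN(C3=NC(=O)CS3)C(c3ccccc3)C2)cc1C` carries hydrogen on the aromatic carbon where compound 2 `Cc1ccc(C2=NN(C3=NC(=O)CS3)C(c3cccc(Cl)c3)C2)cc1C` carries chloro and compound 3 `Cc1ccc(C2=NN(C3=NC(=O)CS3)C(c3ccc(Br)cc3)C2)cc1C` carries bromo. In an ADME assay on RAW264.7 cells (Mus musculus) for cytotoxicity, read by MTT assay, with a stated time of 24 h (a lower number here means that less compound is tolerated, a higher number that more compound is tolerated), compound 1 gives only a limit, > 450000 nM, sitting at the limit of > 450000 nM in this assay, at which 1 of the 3 values shown sits. Compound 2 gives 178000 nM in this assay, and compound 3 gives 365000 nM. Compound 3 therefore holds the higher of the two numbers that are known: a 2.1-fold higher number from compound 2 to compound 3 (0.31 log units; beyond the scatter). Against compound 1, the change to chloro reads an at least 2.5-fold lower number from compound 1 to compound 2 (0.40 log units; beyond the scatter), beyond the scatter, while the change to bromo reads an at least 1.2-fold lower number from compound 1 to compound 3 (0.09 log units; that floor lies within the scatter), a floor that stays within the scatter.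

Compound 4 `Cc1ccc(C2=NN(C3=NC(=O)CS3)C(c3ccc(F)cc3)C2)cc1C` differs from compound 3 by fluoro in place of bromo on an aromatic carbon. Among the measured compounds shown here, the steps that bear on it are the two halogen-for-hydrogen steps, an at least 2.5-fold lower number from compound 1 to compound 2 (0.40 log units; beyond the scatter) and an at least 1.2-fold lower number from compound 1 to compound 3 (0.09 log units; that floor lies within the scatter): one modest, the other within the scatter. Exchanging one halogen for another on the same aromatic carbon is expected to move the number in this assay no more than those did, so a step of no more than modest size, tending slightly upward toward the limit, is expected for compound 4: a 1.1-fold higher number from compound 3 to compound 4 (0.04 log units; within the scatter). Compound 4 is thus estimated at 400000 nM in this assay, with a range from 180000 nM to 450000 nM.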

Compound 4, half-maximal cytotoxic concentration: 246000 nM
Compound 4: the middle estimate sits 1.6-fold (0.21 log units) above what was measured; the range from low to high includes it.
By their numbers in this assay, from the lowest: compounds 2, 4 and 3 (each within the scatter of the next, the first and the last beyond it). At a limit, above all of these: compound 1.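

In this assay, among the compounds shown here, this is the first exchange of one halogen for another on the same aromatic carbon, and 4-fluorophenyl in place of 4-bromophenyl stays within the scatter: a 1.5-fold lower number from compound 3 to compound 4 (0.17 log units; within the scatter). The step from the 3-chlorophenyl compound also stays within the scatter, a 1.4-fold higher number from compound 2 to compound 4 (0.14 log units; within the scatter), so compound 4 cannot be told apart from compound 2 or from compound 3, although those two differ beyond the scatter; against the unsubstituted phenyl of compound 1, fluoro reads an at least 1.8-fold lower number from compound 1 to compound 4 (0.26 log units; that floor lies within the scatter), a floor that does not show whether fluoro at this position moves the number at all. Compound 1 gives a limit and not a number: the limit of > 450000 nM in this assay, at which 1 of the 4 values shown sits.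

Still open, from the compounds shown here alone, is whether the gap between compound 2 and compound 3 follows the halogen or its place on the ring, a question on which a 4-chlorophenyl group would bear. Also open, going by these compounds, is how an amine, a carboxylic acid or a methoxy group on this aromatic carbon would read in this assay.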